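Methoxy to Hydroxy on a Cyclohexyl Amidine Scaffold

The source may hold more compounds than are shown below. What is called first, only, known or untested is meant among the compounds shown, and "the series" means these compounds.

Compound 1 `COc1ccc(Cn2c(-c3ccccc3)c(-c3ccccc3)c3c(=N)n(CC4CCOCC4)cnc32)cc1`: 1270 10^-6 cm/s
Compound 2 `O[C@H]1CC[C@H](Nc2ncnc3c2c(-c2ccccc2)c(-c2ccccc2)n3Cc2ccccc2)CC1`: "nd" (no result reported)
Compound 3 `COc1ccc(-c2c(-c3ccc(OC)cc3)n(Cc3ccccc3)c3ncn([C@H]4CC[C@H](OC)CC4)c(=N)c23)cc1`: > 1000 10^-6 cm/s

In an ADME assay for permeability, using PAMPA, with a stated time of 30 min, at pH 7.4 (on this read-out lower numbers stand for lower permeability and higher numbers for higher permeability), compound 1 gives 1270 10^-6 cm/s. For compound 2 no result is reported, "nd" (no result reported). For compound 3 the assay reports only a limit, > 1000 10^-6 cm/s, and compound 3 therefore stands at the limit of > 1000 10^-6 cm/s in this assay, at which 1 of the 3 values shown sits, not at a single number. Compound 4 `COc1ccc(-c2c(-c3ccc(OC)cc3)n(Cc3ccccc3)c3ncn([C@H]4CC[C@H](O)CC4)c(=N)c23)cc1` differs from compound 3 by hydrogen in place of methyl on an oxygen on a saturated carbon. Within the data shown here, no step between two measured compounds is available, so the size of this change can only be expected, not read from the data. Compound 4 is expected to give 400 10^-6 cm/s, between 150 10^-6 cm/s and 1000 10^-6 cm/s. The expected step is an at least 2.5-fold lower number from compound 3 to compound 4 (0.39 log units; beyond the scatter), a decrease beyond the scatter.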

Compound 4, apparent permeability: 196 10^-6 cm/s
The estimate for compound 4 lay 2.0-fold (0.31 log units) above the measured number, within the range that was stated.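

Among these compounds, changing 4-methoxycyclohexyl to 4-hydroxycyclohexyl gives the first step that can be read at this position: in this assay the change gives an at least 5.1-fold lower number from compound 3 to compound 4 (0.70 log units; beyond the scatter). With the rest of the molecule the same, hydrogen in place of methyl on this oxygen is enough to move the read-out beyond the scatter. The entry for compound 3 is a limit and not a number, so the step has a bound and no exact size: the limit of > 1000 10^-6 cm/s in this assay, at which 1 of the 4 values shown sits. As far as these compounds go, what an amine or a carboxylic acid would give in place of the hydroxy stays open. So does whether a longer chain on this oxygen would move the read-out further.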